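A few compounds are considered here, and "the series" means these few. Any claim that something is new, unique, unknown or untested is made for them only; others in the source may bear on it.

Series notes. The two measured compounds share one core with an ester on a carbonyl carbon. Compound 1 `O=C(OC1(C(=O)Nc2ccc([N+](=O)[O-])cc2)CCCCC1)c1ccc(C(F)(F)F)cc1` carries 4-(trifluoromethyl)phenyl on that carbonyl carbon; in a functional assay on MCF7 cells (Homo sapiens) for inhibition, read by MTT assay, with a stated time of 72 h (on this read-out lower numbers stand for stronger inhibition and higher numbers for weaker inhibition), compound 1 gives 27.1 nM. Compound 2 `O=C(OC1(C(=O)Nc2ccc([N+](=O)[O-])cc2)CCCCC1)c1ccccc1I` carries 2-iodophenyl there, and in this assay compound 2 gives 619 nM. Going by the values given here, compound 2 thus stands at the highest of the two numbers so far, its only neighbour being compound 1, and the one measured step, a 23-fold higher number from compound 1 to compound 2 (1.36 log units; beyond the scatter), is large and runs toward weaker inhibition.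

Compound 3 `O=C(OC1(C(=O)Nc2ccc([N+](=O)[O-])cc2)CCCCC1)c1ccc([N+](=O)[O-])cc1` is the next member. Its change from compound 2 is 4-nitrophenyl in place of 2-iodophenyl on a carbonyl carbon. Among the compounds with values here, the only step that bears on it is a 23-fold higher number from compound 1 to compound 2 (1.36 log units; beyond the scatter), which shows that exchanging the aryl group on this carbonyl carbon can move the number far beyond the scatter. Compound 3 carries 4-nitrophenyl, a group named like the 4-(trifluoromethyl)phenyl of compound 1 rather than the 2-iodophenyl of compound 2, so a step back toward lower numbers, of a size near the recorded one, is expected: a 10-fold lower number from compound 2 to compound 3 (1.01 log units; beyond the scatter). Compound 3 is therefore estimated in this assay at 60 nM, with a range of 15 nM to 250 nM.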

Compound 3, half-maximal inhibitory concentration: 8.7 nM
For compound 3 the middle estimate is 6.9-fold (0.84 log units) above the measured one, outside the stated range (below it).
By their numbers in this assay, from the lowest: compound 3; then compound 1; then compound 2.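

In this assay, the aryl exchange on this carbonyl carbon now has a second large step, a 71-fold lower number from compound 2 to compound 3 (1.85 log units; beyond the scatter), and it runs back toward stronger inhibition, so the high number of compound 2 is not shared by the other two aryl esters. The step of a 3.1-fold lower number from compound 1 to compound 3 (0.49 log units; beyond the scatter) is modest but beyond the scatter; with the ring kept, nitro in place of trifluoromethyl on an aromatic carbon still moves the number, which makes compound 3 the strongest of the three in this assay. No measurement shown accounts for either step.

Compound 2 differs from compound 1 and compound 3 both in its substituent and in where that substituent sits, so these compounds cannot show which of the two changes matters. Also open, on these data alone, is how an amine, a carboxylic acid or a plain alkyl chain would read on this carbonyl carbon in this assay, and whether an aromatic ring is needed there at all.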